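Nitro for propanoylamino: a cytotoxicity step carried over

A few compounds are considered here, and "the series" means these few. Any claim that something is new, unique, unknown or untested is made for them only; others in the source may bear on it.

Measured compounds:
compound 1, `COc1ccc(C(=O)Nc2ccc(N(C)C)cc2)cc1[N+](=O)[O-]`, 88200 nM
compound 2, `CCC(=O)Nc1cc(C(=O)Nc2ccc(OC)cc2)ccc1OC(C)C`, 113000 nM
compound 3, `CCC(=O)Nc1cc(C(=O)Nc2ccc(N(C)C)cc2)ccc1OC`, 171000 nM

In a toxicity assay on Huh-7.5 cells (Homo sapiens) for inhibition, read by MTT assay, with a stated time of 96 h (a higher number here means that more compound is tolerated, a lower number that less compound is tolerated), compound 3 gives 171000 nM, and compound 1 gives 88200 nM. The two differ by one change, (nitro in place of propanoylamino on an aromatic carbon), and the step that it made is a 1.9-fold lower number from compound 3 to compound 1 (0.29 log units; within the scatter). Compound 2 gives 113000 nM in this assay; how its core differs from the core of compound 3 is not broken down here.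

Compound 4, `COc1ccc(NC(=O)c2ccc(OC(C)C)c([N+](=O)[O-])c2)cc1`, has not yet been measured in this assay. It differs from compound 2 by nitro in place of propanoylamino on an aromatic carbon. For the measured compounds named here, this is the same kind of change as the one from compound 3 to compound 1, not the same: in compound 4 the nitro sits ortho to an isopropoxy group, whereas in compound 1 it sits ortho to a methoxy group. The earlier step, a 1.9-fold lower number from compound 3 to compound 1 (0.29 log units; within the scatter), lies within the scatter, so the expected step from compound 2 to compound 4 is also small, a 1.4-fold lower number from compound 2 to compound 4 (0.15 log units; within the scatter). Compound 4 is therefore estimated to give 80000 nM in this assay, with a likely range from 40000 nM to 160000 nM.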

Compound 4, half-maximal cytotoxic concentration: 23400 nM
The estimate for compound 4 lay 3.4-fold (0.53 log units) above the measured number, and the stated range ends above it.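

In this assay the second use of nitro in place of propanoylamino gives a 4.8-fold lower number from compound 2 to compound 4 (0.68 log units; beyond the scatter) and so stands beside the earlier 1.9-fold lower number from compound 3 to compound 1 (0.29 log units; within the scatter) on the other core. The two steps cannot be told apart, so nothing here separates the size of the step on one core from its size on the other: the same change on two cores in this assay, a 1.9-fold lower number (0.29 log units; within the scatter) from compound 3 to compound 1 and a 4.8-fold lower number (0.68 log units; beyond the scatter) from compound 2 to compound 4, 2.5-fold (0.40 log units) apart, within the scatter of two such steps. For the compounds shown here, this shows only that the two pairs are compatible with a single step carried between these cores; with just two pairs, and only one step beyond the scatter, it does not fix the size of that step or show that it would hold on any further core.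

The compounds shown leave open how a nitrile or a carboxylic acid would compare with nitro and propanoylamino at this place on the ring. They also leave open whether the step would stay the same with a longer alkoxy chain in place of the isopropoxy group.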